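This account rests on a few compounds, and the source may have more. Where it says the series, first, only, none or still open, it means among the compounds named here.

Measured so far in a functional assay on the whole organism with Rattus norvegicus as the target; a lower number here means that less compound is needed, a higher number that more compound is needed for the effect:
compound 1 `CCCCCCCc1ccc(CCC(N)(CO)CO)cc1`: 0.1 mg/kg
compound 2 `CCCCCCCCCCc1ccc(CCC(N)(CO)CO)cc1`: 0.1 mg/kg

Compound 2 stands level with compound 1 in this assay; the step of no change at the digits printed from compound 1 to compound 2 (within the scatter) stayed within the scatter even though it put propyl in place of hydrogen on a saturated chain carbon, seven bonds along the chain from an aromatic carbon. Compound 3 `CCCCCCCCCCCc1ccc(CCC(N)(CO)CO)cc1` differs from compound 2 by methyl in place of hydrogen on a saturated chain carbon, ten or more bonds along the chain from an aromatic carbon. For the measured compounds named here, the only step that bears on it, no change at the digits printed from compound 1 to compound 2 (within the scatter), was a larger lengthening of the same chain and gave no change, so no movement beyond the scatter is expected in this assay here. For compound 3 the value expected in this assay is 0.1 mg/kg, range 0.05 mg/kg to 0.2 mg/kg, an expected step of no change at the digits printed from compound 2 to compound 3 (within the scatter).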

Compound 3, dose for 50% inhibition: 0.1 mg/kg
Beside the measured number, compound 3's estimate shows no gap at the digits printed; low and high end bracket the measured number.
By their numbers in this assay, from the lowest: compounds 1, 2 and 3 (each within the scatter of the next).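

In this assay a saturated chain carbon takes methyl in place of hydrogen with no change at the digits printed from compound 2 to compound 3 (within the scatter), so the level reading now reaches this far out on the chain. Taken as a whole, the lengthening reads no change at the digits printed from compound 1 to compound 3 (within the scatter), which extends the flat stretch beyond what the first step covered. No supporting data bear on this flat reading.

Still open, from the compounds shown here alone, is whether a longer chain holds the same level. Also open, going by these compounds, is whether a terminal carboxylic acid or amine on the chain leaves the reading unchanged.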